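A few compounds are considered here, and "the series" means these few. Any claim that something is new, unique, unknown or untested is made for them only; others in the source may bear on it.

Compound 1 `COc1ccc(/C=C/C(=O)c2ccc(OC)c([N+](=O)[O-])c2)cc1` is tested in a functional assay on B16 cells (Mus musculus) for cytotoxicity, read by MTT assay, with a stated time of 3 days (a higher number here means a weaker inhibitor, a lower number a stronger inhibitor), where compound 1 gives > 100000 nM, which is a limit of the assay and not a measured number. Compound 1 therefore stands at the limit of > 100000 nM in this assay, at which 1 of the 3 values shown sits, and how much weaker it truly is cannot be read from the numbers. Two related compounds are measured alongside it. Compound 2 `COc1ccc(/C=C/C(=O)c2ccc(OC)c(N)c2)cc1` carries an amino group where compound 1 carries a nitro group; in this assay compound 2 gives 43000 nM, and that is an at least 2.3-fold lower number from compound 1 to compound 2 (0.36 log units; beyond the scatter). Compound 3 `COc1cc(/C=C/C(=O)c2ccc(OC)c([N+](=O)[O-])c2)cc(OC)c1`, with a different methoxy pattern on one ring, gives 5600 nM.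

The compound now in question is compound 4 `COc1ccc(/C=C/C(=O)c2ccc(OC)c([N+](=O)[O-])c2)cc1OC`. It differs from compound 1 by a single change: methoxy in place of hydrogen on an aromatic carbon. Within the data shown here, none of the measured steps involves this change; the only measured step, from compound 1 to compound 2, alters the nitro group and gives no direct guidance on adding a methoxy. What the numbers show is this. Compound 1 stands at a limit. Compound 3, carrying more methoxy groups than compound 1, gives a finite number. On that basis the expected step is an at least 6.6-fold lower number from compound 1 to compound 4 (0.82 log units; beyond the scatter), moving below the limit. Compound 4 is estimated at 15000 nM in this assay, with a range from 3000 nM to 80000 nM.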

Compound 4, half-maximal inhibitory concentration: > 100000 nM
Compound 4 ended at the assay's limit; the forecaster's own chance of this, stated with the estimate: 20%; at least 6.6-fold (0.82 log units) between middle value and limit.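

No step can be read from compound 1 to compound 4, because each of them stands at a limit of the assay and not at a measured number: the limit of > 100000 nM in this assay, at which 2 of the 4 values shown sit. The compounds shown leave open whether methoxy in place of hydrogen on an aromatic carbon changes the true strength of compound 1 at all, and by how much.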